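The source may report more compounds than this note shows. Statements on the series, on what has been measured and on what is new or still open speak of the compounds shown alone.

In a functional assay on B16-F10 cells (Mus musculus) for antiproliferative activity, read by MTT assay, with a stated time of 48 h (a higher number here means a weaker inhibitor, a lower number a stronger inhibitor), compound 1 (`CCCCCCOc1ccc(C(=O)/C=C/c2c(/C=C/c3ccc(OC)cc3)cc(OC)cc2OC)cc1`) gives 10.4 ug/mL and compound 2 (`COc1ccc(/C=C/c2cc(OC)cc(OC)c2/C=C/C(=O)c2cccc(Cl)c2)cc1`) gives 3.3 ug/mL while compound 3 (`CCOc1ccc(C(=O)/C=C/c2c(/C=C/c3ccc(OC)cc3)cc(OC)cc2OC)cc1`) gives 6.4 ug/mL as the middle one of the three numbers. Both measured steps that reach compound 3 lie within the scatter.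

Next in the series is compound 4 (`COc1ccc(/C=C/c2cc(OC)cc(OC)c2/C=C/C(=O)c2ccc(-c3ccccc3)cc2)cc1`). It differs from compound 3 by phenyl in place of ethoxy on an aromatic carbon, para to a large group (phenyl in place of ethoxy on an aromatic carbon). Cut one bond further out, the same difference reads 4-ethoxyphenyl to 4-phenylphenyl.

For the measured compounds named here, two measured steps bear on this change. Hydrogen in place of butyl on the saturated chain gave a 1.6-fold lower number from compound 1 to compound 3 (0.21 log units; within the scatter) and 4-ethoxyphenyl in place of 3-chlorophenyl on the carbonyl carbon gave a 1.9-fold higher number from compound 2 to compound 3 (0.29 log units; within the scatter) so neither step leaves the scatter. Going by the values given here, no measured compound carries phenyl at this place, which makes the reading indirect. No step beyond the scatter is therefore expected in this assay and no direction is favoured. The estimated step is a 1.1-fold lower number from compound 3 to compound 4 (0.03 log units; within the scatter) and it is expected to stay inside the scatter. For compound 4 the expected value is 6 ug/mL (estimated range 2.5 ug/mL to 14 ug/mL).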

Compound 4, half-maximal inhibitory concentration: 10.6 ug/mL
Estimate against measurement, compound 4: 1.8-fold (0.25 log units) below; the range from low to high includes it.
By their numbers in this assay, from the lowest: compounds 2, 3, 1 and 4 (each within the scatter of the next, the first and the last beyond it).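

In this assay, phenyl in place of ethoxy on this aromatic carbon, para to a large group, gives a 1.7-fold higher number from compound 3 to compound 4 (0.22 log units; within the scatter), so bringing a six-membered aromatic ring of carbon only to this place, with no oxygen attached there, does not move the number outside the scatter. Phenyl in place of hexyloxy at the same carbon gives a 1.0-fold higher number from compound 1 to compound 4 (0.01 log units; within the scatter), which means that ethoxy, hexyloxy and phenyl cannot be told apart here by their steps, despite their different shapes and sizes as named groups. For the compounds shown here, the wider exchange, 4-phenylphenyl in place of 3-chlorophenyl on the carbonyl carbon, gives a 3.2-fold higher number from compound 2 to compound 4 (0.51 log units; beyond the scatter); this is the only step in the set that lies beyond the scatter, and it is modest. This step replaces the whole aryl group. It does not separate the effect of the substituent from that of where it sits.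

As far as these compounds go, whether an amine, a carboxylic acid or a plain hydrogen on this aromatic carbon would produce a step beyond the scatter remains open, as does how 4-chlorophenyl would compare with 3-chlorophenyl on the carbonyl carbon. Nothing among the data available gives a measured reason for any of these numbers.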